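The source may hold more compounds than are shown below. What is called first, only, known or untested is meant among the compounds shown, and "the series" means these compounds.

Measured so far:
compound 1 `C=CC(=O)Nc1ccc(-c2nc(Cl)cc(Nc3ccc(C(=O)N(CC)CC)cc3)n2)cc1` gives 9340 nM in a functional assay on HL-60 cells (Homo sapiens) for antiproliferative activity, read by MTT assay, with a stated time of 48 h; on this read-out higher numbers stand for weaker inhibition and lower numbers for stronger inhibition;
compound 2 `C=CC(=O)Nc1ccc(-c2nc(Cl)cc(Nc3ccc(C(=O)Nc4cccc(C)c4)cc3)n2)cc1` gives 3660 nM in this assay.

Among the measured compounds shown here, compound 2 holds the lowest of the two numbers, and the one step leading to it, a 2.6-fold lower number from compound 1 to compound 2 (0.41 log units; beyond the scatter), lies beyond the scatter. Compound 3 `C=CC(=O)Nc1ccc(-c2nc(Cl)cc(Nc3ccc(C(=O)N4CCCC4)cc3)n2)cc1` differs from compound 2 by pyrrolidin-1-yl in place of (3-methylphenyl)amino on a carbonyl carbon. The entering pyrrolidin-1-yl group resembles the diethylamino group of compound 1 more than the (3-methylphenyl)amino group it replaces, so the step of a 2.6-fold lower number from compound 1 to compound 2 (0.41 log units; beyond the scatter) is expected to run partly in reverse. Compound 3 is therefore expected to give 7000 nM in this assay, within 3000 nM to 16000 nM, with a 1.9-fold higher number from compound 2 to compound 3 (0.28 log units; within the scatter) as the expected step.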

Compound 3, half-maximal inhibitory concentration: 15800 nM
Compound 3: middle estimate off by 2.3-fold (0.35 log units), on the low side; measured number inside the range.
By their numbers in this assay, from the lowest: compound 2; then compounds 1 and 3 (each within the scatter of the next).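

In this assay, pyrrolidin-1-yl in place of (3-methylphenyl)amino on the carbonyl carbon gives a 4.3-fold higher number from compound 2 to compound 3 (0.64 log units; beyond the scatter) and so confirms that this position responds to the amine part of the amide. Pyrrolidin-1-yl in place of diethylamino gives a 1.7-fold higher number from compound 1 to compound 3 (0.23 log units; within the scatter) and the two groups cannot be told apart here. No measurement offers an explanation for either step. On these data alone, the change from compound 2 to compound 3 removes the aromatic ring and the amide hydrogen together, so which of them matters stays open. A cyclohexylamino group, with its non-aromatic ring and amide hydrogen, would help separate them.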